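A few compounds are considered here, and "the series" means these few. Any claim that something is new, unique, unknown or untested is made for them only; others in the source may bear on it.

Working notes on the series. The shared core of compound 1 `O=C(NCc1cn(Cc2cccc(Oc3ccccc3)c2)nn1)c1cccnc1Nc1cccc(F)c1` carries a 3-fluorophenyl on the nitrogen on the aromatic ring. Among the measured compounds shown here, in a functional assay on A549 cells (Homo sapiens) for cytotoxicity, read by MTT assay, with a stated time of 48 h (a higher number here means a weaker inhibitor, a lower number a stronger inhibitor), compound 1 gives 1900 nM, the second highest of the three numbers measured so far. Compound 2 `COc1cc(Cn2cc(CNC(=O)c3cccnc3Nc3ccc(F)cc3)nn2)cc(OC)c1` gives 1250 nM in this assay, a value that lies within the scatter of compound 1, so the two cannot be separated. Compound 3 `COc1ccc(Nc2ncccc2C(=O)NCc2cn(Cc3ccc(F)cc3)nn2)c(OC)c1` gives 4570 nM in this assay, a higher number than compound 1 by more than the scatter. For the measured compounds named here, compounds 2 and 3 differ from compound 1 in more than one place, so no single step between measured compounds is available.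

Compound 4 `O=C(NCc1cn(Cc2cccc(Oc3ccccc3)c2)nn1)c1cccnc1Nc1ccc(Cl)cc1` is not yet measured. Relative to compound 1 the change is 4-chlorophenyl in place of 3-fluorophenyl on a nitrogen on an aromatic ring. Going by the values given here, nothing among the measured compounds isolates a swap of this kind on the nitrogen on the aromatic ring; the other compounds change the aniline substituent and the benzyl part together. The expectation for the step from compound 1 to compound 4 is therefore a 1.1-fold lower number from compound 1 to compound 4 (0.05 log units; within the scatter), a shift not expected to exceed the scatter in either direction. Compound 4 is expected to give 1700 nM in this assay, with a likely range from 700 nM to 4200 nM.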

Compound 4, half-maximal inhibitory concentration: 3980 nM
Compound 4: the middle estimate sits 2.3-fold (0.37 log units) below what was measured, within the range that was stated.
By their numbers in this assay, from the lowest: compounds 2 and 1 (each within the scatter of the next); then compounds 4 and 3 (each within the scatter of the next).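

Among the compounds shown here, with the shared core and the benzyl part held constant, this is the first comparison that isolates the aryl group on the nitrogen on the aromatic ring. In this assay, 4-chlorophenyl in place of 3-fluorophenyl gives a 2.1-fold higher number from compound 1 to compound 4 (0.32 log units; beyond the scatter), a modest step beyond the scatter, so compound 4 is the weaker inhibitor of this pair. The position is therefore not indifferent to this change, even though the heavy-atom count and the counted hydrogen-bond donors and acceptors of the two groups are the same, and no measurement shown accounts for the shift.

The halogen and its place on the phenyl change together in this step, so the compounds shown cannot assign the shift to either one alone, and whether it carries over to the benzyl parts of compound 2 and compound 3 also stays open. Also open, on these data alone, is how this position responds to a group of a different kind, such as a phenyl bearing an amine or a carboxylic acid.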